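A few compounds are considered here, and "the series" means these few. Any claim that something is new, unique, unknown or untested is made for them only; others in the source may bear on it.

Measured so far:
compound 1, `C[C@@H]1COC(c2cccc(OC(=O)NC3CCCCC3)c2)=N1`, 16%
compound 2, `O=C(NC1CCCCC1)Oc1cccc(C2=N[C@@H](Cc3ccccc3)CO2)c1`, 17%

Both compounds were tested in an assay on membranes from cerebellum (strain Wistar) for inhibition of Monoglyceride lipase (Rattus norvegicus), read by HPLC, tested at 100 uM; on this read-out lower numbers stand for less inhibition and higher numbers for more inhibition at the one concentration tested (going by the name of the read-out). In this assay compound 1 gives 16% and compound 2 gives 17%. Going by the values given here, these two numbers lie within the usual scatter of each other, so compound 2 is not distinguished from compound 1 on what has been measured; no step between measured compounds is available that would show how a change of configuration at the saturated ring carbon bears on this assay.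

The next compound, compound 3, `O=C(NC1CCCCC1)Oc1cccc(C2=N[C@H](Cc3ccccc3)CO2)c1`, is to be measured in this assay. Relative to compound 2 the change is the two compounds have the same atoms and bonds and differ only in configuration as drawn: 1 of 1 stereo elements differ; a stereocentre at a saturated ring carbon is drawn S in compound 2 and R in compound 3.

Among the compounds with values here, since nothing measured so far tells how the configuration at this centre affects the read-out, the expected step of a number 2 percentage points lower from compound 2 to compound 3 (within the scatter) is set at none beyond the scatter, in either direction. On that basis compound 3 is expected in this assay at 15%, with a range from 4% to 30% that allows for the scatter and for a possible shift in either direction.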

Compound 3, a percentage reported as inhibition, at one concentration (the size of the read-out at that concentration, not a potency): 14%
Compound 3: middle estimate off by 1 percentage points, on the high side; low and high end bracket the measured number.
By their numbers in this assay, from the lowest: compounds 3, 1 and 2 (each within the scatter of the next).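

In this assay, moving the stereocentre at the saturated ring carbon from S to R gives a number 3 percentage points lower from compound 2 to compound 3 (within the scatter), so on these numbers the configuration at this position is not separated from the scatter at the one concentration tested. The pair reads this centre alone, with no other structural change in play: the fact that compounds 2 and 3 differ only in the configuration as drawn. Phenyl in place of hydrogen on a saturated chain carbon bound to a saturated ring carbon gives a number 2 percentage points lower from compound 1 to compound 3 (within the scatter), so this change at the same position is also not separated from the scatter, and neither the configuration nor this substituent change yet offers a handle on the read-out.

As far as these compounds go, whether an amine, a carboxylic acid or a longer chain on that saturated chain carbon would move the number beyond the scatter stays open. Also open, from the compounds shown here alone, is whether the two configurations would separate with such a group in place, or at another concentration, since a reading at a single concentration gives no potency.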